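The source may hold more compounds than are shown below. What is called first, only, known or untested is meant among the compounds shown, and "the series" means these compounds.

Among the measured compounds shown here, compound 2 `COc1cc(NC(C)CCCNC(=O)C2CCC3(CC2)OOC2(OO3)C3CC4CC(C3)CC2C4)c2ncccc2c1-c1ccc(Cl)cc1` gives 10.7 uL/min in an ADME assay on microsomes from liver (Rattus norvegicus) for metabolic stability, read by HPLC, using NADPH, tested at 1 mM (on this read-out higher numbers stand for fast clearance and lower numbers for slow clearance), the lowest of the two numbers measured so far. For the measured compounds named here, its nearest neighbour is compound 1 `COc1cc(NC(C)CCCNC(=O)C2CCC3(CC2)OOC2(OO3)C3CC4CC(C3)CC2C4)c2ncccc2c1-c1ccc(F)cc1`, which gives 34.6 uL/min in this assay; the step of a 3.2-fold lower number from compound 1 to compound 2 (0.51 log units; beyond the scatter) is the only comparison available, and it is a modest one that lies beyond the scatter.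

Compound 3 `COc1cc(NC(C)CCCNC(=O)C2CCC3(CC2)OOC2(OO3)C3CC4CC(C3)CC2C4)c2ncccc2c1-c1ccc(C(F)(F)F)cc1` differs from compound 2 in one place: trifluoromethyl in place of chloro on an aromatic carbon. Going by the values given here, no measured pair shows the chloro-to-trifluoromethyl exchange itself, so the expectation for compound 3 rests on the single step from fluoro to chloro. That step a 3.2-fold lower number from compound 1 to compound 2 (0.51 log units; beyond the scatter) lowered the number, but it is a different exchange at the same aromatic carbon and cannot be carried over directly. The account therefore expects a step of a 1.2-fold lower number from compound 2 to compound 3 (0.08 log units; within the scatter) for compound 3 that is small and within the usual scatter, with no confident direction. On this basis compound 3 is estimated at 9 uL/min in this assay, with a range from 4 uL/min to 22 uL/min that allows for a modest move either way.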

Compound 3, intrinsic clearance in a liver preparation (reported as CLH), per the amount of preparation that the assay uses: 13.9 uL/min
For compound 3 the middle estimate is 1.5-fold (0.19 log units) below the measured one, and the stated range covers the measured number.
By their numbers in this assay, from the lowest: compounds 2 and 3 (each within the scatter of the next); then compound 1.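

With trifluoromethyl now at this aromatic carbon, para to a large group, the 4-phenyl substituent series gains a second exchange, and in this assay it shows a 1.3-fold higher number from compound 2 to compound 3 (0.11 log units; within the scatter), so chloro and trifluoromethyl cannot be told apart here even though the entering group holds more heavy atoms. The fluoro compound now stands apart from two neighbours rather than one: a 2.5-fold lower number from compound 1 to compound 3 (0.40 log units; beyond the scatter) sits beside a 3.2-fold lower number from compound 1 to compound 2 (0.51 log units; beyond the scatter), both beyond the scatter and both pointing the same way, so among these three compounds the one clear separation lies between fluoro and the other two groups. No accompanying measurement bears on what lies behind this separation.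

The compounds shown leave open how a methoxy group, a nitrile or an amine on this aromatic carbon would stand against fluoro, chloro and trifluoromethyl in this assay. They also leave open whether the same separation would hold with a shorter or longer chain in place of the one carried by the shared core.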